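The source may report more compounds than this note shows. Statements on the series, on what has been measured and on what is new or still open speak of the compounds shown alone.

Measured so far:
compound 1, `COc1ccc(C2=Nc3c(C(C)(C)C)nn(CCCO)c3C(=O)NC2)cc1-c1cnn(C)c1`, 2 h in an ADME assay on microsomes from liver (Homo sapiens) for metabolic stability; on this read-out higher numbers stand for a longer-lived compound and lower numbers for a shorter-lived compound
compound 2, `COc1ccc(C2=Nc3c(C(C)(C)C)nn(CCCO)c3C(=O)NC2)cc1-c1ccc(F)cc1F`, 2 h in this assay

Compound 2 stands level with compound 1: the step of no change at the digits printed from compound 1 to compound 2 (within the scatter), so exchanging one aromatic ring for another at that position left the half-life where it was.

Compound 3, `COc1ccc(-c2cc(C3=Nc4c(C(C)(C)C)nn(CCCO)c4C(=O)NC3)ccc2OC)c(OC)c1`, is the next step. The change from compound 2 is 2,4-dimethoxyphenyl in place of 2,4-difluorophenyl on an aromatic carbon. Going by the values given here, the only measured step that touches the same position is the one from compound 1 to compound 2, which was flat within the scatter, and nothing else in the data concerns the groups involved here. On that basis no step beyond the scatter is expected, and compound 3 is estimated to remain close to compound 2, with a 1.1-fold lower number from compound 2 to compound 3 (0.05 log units; within the scatter). The expected half-life for compound 3 in this assay is therefore 1.8 h, in a range from 0.8 h to 3.5 h.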

Compound 3, half-life: 2 h
Beside the measured number, compound 3's estimate is 1.1-fold (0.05 log units) below it, within the range that was stated.
By their numbers in this assay, from the lowest: compounds 1, 2 and 3 (each within the scatter of the next).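

Measured in this assay putting 2,4-dimethoxyphenyl in place of 2,4-difluorophenyl on this aromatic carbon, ortho to a methoxy group, moves nothing (no change at the digits printed from compound 2 to compound 3 (within the scatter)). This holds although the entering group has 10 heavy atoms against 8 and carries 2 hydrogen-bond acceptors where the group leaving has 0, and the comparison with the pyrazole-bearing compound is just as flat (no change at the digits printed from compound 1 to compound 3 (within the scatter)). Nothing available explains why the half-life stays level across these three aromatic rings.

Going by these compounds, all three groups at this position are aromatic rings, so it remains open how a phenyl ring carrying an amine or a carboxylic acid, or a saturated ring such as morpholine, would behave here. Every compound shown also shares the same remaining structure, so changes elsewhere in the molecule remain open too.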